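A few compounds are considered here, and "the series" means these few. Any claim that something is new, unique, unknown or untested is made for them only; others in the source may bear on it.

Three compounds have been measured in an assay on IM-9 cells for displacement of a labelled ligand from Substance-P receptor (Homo sapiens), read by scintillation counting, with a stated time of 30 min; a lower number here means a stronger inhibitor, a higher number a weaker inhibitor:
compound 1 `CC(=O)N1CC[C@H](C(=O)N(C)Cc2cc(C(F)(F)F)cc(C(F)(F)F)c2)[C@H](c2ccccc2)C1` gives 3.2 nM;
compound 2 `CCc1ccccc1[C@H]1CN(C(=O)C2CCN(C(C)=O)CC2)CC[C@@H]1C(=O)N(C)Cc1cc(C(F)(F)F)cc(C(F)(F)F)c1` gives 0.064 nM;
compound 3 `CC(=O)NCC(=O)N1CC[C@H](C(=O)N(C)Cc2cc(C(F)(F)F)cc(C(F)(F)F)c2)[C@@H](c2ccc(F)cc2C)C1` gives 0.043 nM.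

Compound 3 shows the lowest of the three numbers, yet its gap to compound 2 lies within the usual scatter, while its gap to compound 1 lies well beyond it. Compound 4 `CNC(=O)C(=O)N1CC[C@H](C(=O)N(C)Cc2cc(C(F)(F)F)cc(C(F)(F)F)c2)[C@@H](c2ccc(F)cc2C)C1` has not yet been measured. It differs from compound 3 in one place: methylcarbamoyl in place of acetamidomethyl on a carbonyl carbon. Among the measured compounds shown here, no measured pair shows this exact change, so the expectation rests only on the close count of heavy atoms and the matching count of hydrogen-bond donors and acceptors in the two groups. The step from compound 3 to compound 4 in this assay is expected to be small, a 1.9-fold higher number from compound 3 to compound 4 (0.27 log units; within the scatter), at most a slight weakening beyond the scatter. Compound 4 is therefore estimated at 0.08 nM, within a range from 0.03 nM to 0.25 nM.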

Compound 4, half-maximal inhibitory concentration: 0.11 nM
The estimate for compound 4 lay 1.4-fold (0.14 log units) below the measured number, within the range that was stated.
By their numbers in this assay, from the lowest: compounds 3, 2 and 4 (each within the scatter of the next, the first and the last beyond it); then compound 1.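

Among the compounds shown here, this swap gives the first comparison at this position that changes only one group: this assay shows a 2.6-fold higher number from compound 3 to compound 4 (0.41 log units; beyond the scatter) when methylcarbamoyl replaces acetamidomethyl on the carbonyl carbon. The step is modest, yet it lies beyond the scatter, so this position registers even a small change between groups with matching counts of hydrogen-bond donors and acceptors. Nothing at hand accounts for the difference.

From the compounds shown here alone, it remains open how a carboxylic acid, an amine or a longer chain on this carbonyl carbon would compare. Going by these compounds, it is also open whether this step would be the same size on the core of compound 1.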